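A long chain in place of ethyl on compound 1

A few compounds are considered here, and "the series" means these few. Any claim that something is new, unique, unknown or untested is made for them only; others in the source may bear on it.

Compound 1: `CCOc1ccc(C(=O)/C=C/c2c(/C=C/c3ccc(OC)cc3)cc(OC)cc2OC)cc1` gives 8 ug/mL in a functional assay on HepG2 cells (Homo sapiens) for antiproliferative activity, read by MTT assay, with a stated time of 48 h; on this read-out lower numbers stand for stronger inhibition and higher numbers for weaker inhibition.
Compound 2: `COc1ccc(/C=C/c2cc(OC)cc(OC)c2/C=C/C(=O)c2ccc(N)cc2)cc1` gives 7.5 ug/mL in this assay.
Compound 3: `COc1ccc(/C=C/c2cc(OC)cc(OC)c2/C=C/C(=O)c2ccc(C)c(C)c2)cc1` gives 0.2 ug/mL in this assay.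

Compound 1 carries the highest of the three numbers. Its nearest neighbour is compound 2, reached by a 1.1-fold lower number from compound 1 to compound 2 (0.03 log units; within the scatter); compound 3 lies far off, reached by a 40-fold lower number from compound 1 to compound 3 (1.60 log units; beyond the scatter), and a 38-fold lower number from compound 2 to compound 3 (1.57 log units; beyond the scatter) is of the same size. Compound 4, `CCCCCCCCCCCCOc1ccc(C(=O)/C=C/c2c(/C=C/c3ccc(OC)cc3)cc(OC)cc2OC)cc1`, differs from compound 1 by decyl in place of hydrogen on a saturated chain carbon, two bonds along the chain from an oxygen on an aromatic ring. Among the compounds with values here, no measured step alters this chain; the only step that leaves the aryl on the carbonyl carbon unchanged is a 1.1-fold lower number from compound 1 to compound 2 (0.03 log units; within the scatter), which stays within the scatter. Compound 4 is therefore expected to show no step beyond the scatter, no change at the digits printed from compound 1 to compound 4 (within the scatter). Compound 4 is estimated at 8 ug/mL, within 3 ug/mL to 25 ug/mL.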

Compound 4, half-maximal inhibitory concentration: 11.6 ug/mL
Estimate against measurement, compound 4: 1.5-fold (0.16 log units) below, within the range that was stated.
By their numbers in this assay, from the lowest: compound 3; then compounds 2, 1 and 4 (each within the scatter of the next).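

In this assay, within the data shown here, the earlier compounds left this chain untouched; decyl in place of hydrogen on this saturated chain carbon, which reads as ethyl to dodecyl, now gives the first step at this position (a 1.5-fold higher number from compound 1 to compound 4 (0.16 log units; within the scatter)). The position, two bonds along the chain from an oxygen on an aromatic ring, thus carries a dodecyl chain with no change beyond the scatter. No measurement here accounts for this result. The compounds shown leave open whether a butyl or octyl chain, or a chain ending in an amine or a carboxylic acid, would behave the same way.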